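Swapping a hydroxy for a chloro on the aryl ketone

The source may report more compounds than this note shows. Statements on the series, on what has been measured and on what is new or still open speak of the compounds shown alone.

Two compounds share a core and differ only at one position on the ring that carries the ketone. Compound 1 `COc1ccc(C(=O)/C=C/c2cc3ccccc3[nH]c2=O)cc1` bears a methoxy there; compound 2 `O=C(/C=C/c1cc2ccccc2[nH]c1=O)c1ccc(O)cc1` bears a hydroxy. In a functional assay on HOP-62 cells (Homo sapiens) for cytotoxicity, read by sulforhodamine B assay, with a stated time of 24 h (on this read-out higher numbers stand for weaker inhibition of growth and lower numbers for stronger inhibition of growth), compound 1 gives 11600 nM, and compound 2 gives 8170 nM. The step of a 1.4-fold lower number from compound 1 to compound 2 (0.15 log units; within the scatter) is small, so the two numbers sit within the usual scatter of each other and neither compound is set apart by this assay.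

Compound 3 `O=C(/C=C/c1cc2ccccc2[nH]c1=O)c1ccc(Cl)cc1` is the next member, not yet measured. Its change from compound 2 is chloro in place of hydroxy on an aromatic carbon. Within the data shown here, only one measured step concerns this position, the one from compound 1 to compound 2, and it altered the group on the oxygen without moving the number beyond the scatter. Among the measured compounds shown here, no measured pair shows what replacing hydroxy with chloro does here, so the sole guide is that this position has so far tolerated change quietly. The expected step of a 1.1-fold higher number from compound 2 to compound 3 (0.04 log units; within the scatter) is therefore small. Compound 3 is estimated at 9000 nM, with a range from 3000 nM to 27000 nM.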

Compound 3, concentration for total growth inhibition: 44200 nM
Compound 3: middle estimate off by 4.9-fold (0.69 log units), on the low side; measured number outside the range, above it.
By their numbers in this assay, from the lowest: compounds 2 and 1 (each within the scatter of the next); then compound 3.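

In this assay this position turns out not to be indifferent to every change: the step of a 5.4-fold higher number from compound 2 to compound 3 (0.73 log units; beyond the scatter) and the step of a 3.8-fold higher number from compound 1 to compound 3 (0.58 log units; beyond the scatter) both lie beyond the scatter, which leaves the chloro compound as the weakest growth inhibitor of the three. Among these compounds, until now the only change at this position had been between hydroxy and methoxy, two groups joined to the ring through oxygen, and that change left the numbers within the scatter of each other; the first replacement of that oxygen by another atom is also the first step here that exceeds the scatter. Nothing available here explains this rise in the number.

Going by these compounds, with a single chloro compound, it remains open whether this loss belongs to chlorine in particular or would follow any group without oxygen at this position, so the shared core carrying an amine, a methyl or a fluoro there would be informative. On these data alone, it also remains open whether a larger oxygen-linked group, such as ethoxy, would stay with hydroxy and methoxy, or whether a carboxylic acid would behave differently from all three.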